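Swapping (dimethylamino)methyl for pyrrolidin-1-yl on the shared core

The compounds below may be only part of what the source reports. "The series", "measured", "known", "first", "only" and "open" are said of these compounds alone.

Four compounds here share one core and differ in the amine-carrying chain on an oxygen on an aromatic ring. In a functional assay on A549 cells (Homo sapiens) for cytotoxicity, read by MTT assay, with a stated time of 48 h (on this read-out lower numbers stand for stronger inhibition and higher numbers for weaker inhibition), compound 1 (`O=c1cc(-c2ccccc2)oc2c(OCCCCNC3CCCCC3)c(O)cc(O)c12`) is recorded as "not determined" (no result reported) and so offers no result. Compound 2 (`CC(CO)NCCOc1c(O)cc(O)c2c(=O)cc(-c3ccccc3)oc12`) is likewise recorded as "not determined" (no result reported) in this assay and offers none either. Compound 3 (`CN(C)CCCCOc1c(O)cc(O)c2c(=O)cc(-c3ccccc3)oc12`) gives > 100000 nM in this assay and this is a limit of the assay, not a number. Among the measured compounds shown here, no measured step is available to lean on.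

Compound 4 (`O=c1cc(-c2ccccc2)oc2c(OCCCN3CCCC3)c(O)cc(O)c12`) differs from compound 3 in one place: pyrrolidin-1-yl in place of (dimethylamino)methyl on a saturated chain carbon, three bonds along the chain from an oxygen on an aromatic ring. The only anchor is the limit of compound 3 at > 100000 nM and so a small step towards somewhat stronger inhibition is expected in this assay at most. The estimated size is an at least 1.4-fold lower number from compound 3 to compound 4 (0.15 log units; that floor lies within the scatter) and another limit instead of a number would be no surprise. In this assay the expected value for compound 4 is 70000 nM with an estimated range from 20000 nM to 150000 nM at this stage.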

Compound 4, half-maximal inhibitory concentration: > 100000 nM
Compound 4: a limit, no number; the forecaster's own chance of this, stated with the estimate: 50%; at least 1.4-fold (0.15 log units) between middle value and limit.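

Compound 3 and compound 4 both stop at a limit of this assay, not at a number, so no step between them can be read: the limit of > 100000 nM in this assay, at which 2 of the 4 values shown sit.

The compounds shown leave open whether pyrrolidin-1-yl in place of (dimethylamino)methyl changes cytotoxicity at all on the shared core.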